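This account rests on a few compounds, and the source may have more. Where it says the series, first, only, none or still open, it means among the compounds named here.

Measured so far:
compound 1 `CC(C)(CO)[C@H](O)C(=O)N/C=C/C(=O)OCc1ccccc1` — -6%
compound 2 `CC(C)(C)OC(=O)/C=C\NC(=O)[C@H](O)C(C)(C)CO` — -9%
compound 3 `COC(=O)/C=C/NC(=O)[C@@H](O)C(C)(C)CO` — -2%

These three compounds share a core and differ at the ester end. In an ADME assay on HEK293 cells (Homo sapiens) for inhibition, read by CellTiter-Glo, with a stated time of 96 h, tested at 100 uM (a lower number here means less inhibition, a higher number more inhibition at the concentration tested (going by the name of the read-out)), compound 1 gives -6%, compound 2 gives -9% and compound 3 gives -2%. For the measured compounds named here, none of the three shows inhibition in this assay, and compound 3 stands level with the others: the single step measured so far, a number 4 percentage points higher from compound 1 to compound 3 (within the scatter), is within the scatter, and the two values of compound 3 and compound 2 are within the scatter of each other as well.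

Compound 4 `CC(C)(C)OC(=O)/C=C/NC(=O)[C@@H](O)C(C)(C)CO` is the next compound, differing from compound 3 in one place: tert-butyl in place of methyl on an oxygen next to a carbonyl group. Going by the values given here, the one measured step that bears on this position, the change of hydrogen in place of phenyl in a number 4 percentage points higher from compound 1 to compound 3 (within the scatter), did not move the number beyond the scatter, and compound 2, which carries the tert-butyl group already, also shows no inhibition. A step of no size beyond the scatter is therefore expected in this assay, a number 2 percentage points lower from compound 3 to compound 4 (within the scatter). Compound 4 is thus expected to give about -4%, in a range from -16% to 8%.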

Compound 4, a percentage reported as inhibition, at one concentration (the size of the read-out at that concentration, not a potency): -8%
Beside the measured number, compound 4's estimate is 4 percentage points above it; the measured number falls inside the stated range.
By their numbers in this assay, from the lowest: compounds 2, 4, 1 and 3 (each within the scatter of the next).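

In this assay, three different groups on this oxygen can now be compared directly: tert-butyl in place of methyl gives a number 6 percentage points lower from compound 3 to compound 4 (within the scatter), and tert-butyl in place of benzyl gives a number 2 percentage points lower from compound 1 to compound 4 (within the scatter). Among methyl, benzyl and tert-butyl, then, no choice of group on this oxygen separates the compounds. Configuration as drawn also leaves the number within the scatter, with a number 1 percentage points higher from compound 2 to compound 4 (within the scatter), and this comparison reads on configuration alone: the fact that compounds 2 and 4 differ only in the configuration as drawn

From the compounds shown here alone, the stereocentre and the double bond change together in that pair, so the effect of each one alone stays open. Also open, going by these compounds, is whether a carboxylic acid in place of the ester, or an amide carrying an amine on its chain, would give a number beyond the scatter.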